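Swapping methyl for phenyl on a seven-membered aromatic core

This account rests on a few compounds, and the source may have more. Where it says the series, first, only, none or still open, it means among the compounds named here.

Three compounds share the core of compound 1 `CCOC(=O)C(=O)Nc1c(C)ccccc1=O` and differ only in the group on the seven-membered aromatic ring. In a functional assay on the whole organism (strain Sprague-Dawley CD) for inhibition, with Rattus norvegicus as the target, read by paw edema, at a dose of 100 mg/kg by the oral route (on this read-out lower numbers stand for a weaker effect and higher numbers for a stronger effect at the one dose given), compound 1 gives 37%. Compound 2 `CCOC(=O)C(=O)Nc1ccccc(C)c1=O` stands second highest of the three; in this assay compound 2 gives 34%, within the scatter of compound 1. Compound 3 `CCOC(=O)C(=O)Nc1ccccc(N(C)S(=O)(=O)c2ccc(C)cc2)c1=O`, which carries the largest group, gives 0% in this assay, far below the other two. Compound 4 `CCOC(=O)C(=O)Nc1ccccc(-c2ccccc2)c1=O` is the next step: phenyl in place of methyl on an aromatic carbon. Within the data shown here, no measured step of this kind exists here, so the estimate rests on the whole set; the large group of compound 3 with its 0% suggests that added bulk does not help. For compound 4 a step of a number 16 percentage points lower from compound 2 to compound 4 (beyond the scatter) is expected, a drop beyond the scatter. Compound 4 is therefore estimated at 18%, with a range from 0% to 38%.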

Compound 4, a percentage reported as inhibition, in the whole organism at one dose (the size of the read-out at that dose, not a potency): 0%
Compound 4: the middle estimate sits 18 percentage points above what was measured, within the range that was stated.
By their numbers in this assay, from the lowest: compounds 3 and 4 (each within the scatter of the next); then compounds 2 and 1 (each within the scatter of the next).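

Phenyl in place of methyl on an aromatic carbon gives a number 34 percentage points lower from compound 2 to compound 4 (beyond the scatter) in this assay. The effect at this dose is therefore lost with a group of carbon only, so the loss seen with compound 3 is not limited to its group with nitrogen and sulfur. Nothing available here explains why the effect disappears. The compounds shown leave open how much change this position tolerates, since nothing sits in size between methyl and phenyl. An ethyl group, a methoxy group or an amine at this place could begin to answer that.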